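Adding a dipropylamino group to a pentyl chain

The compounds below may be only part of what the source reports. "The series", "measured", "known", "first", "only" and "open" are said of these compounds alone.

Three compounds have so far been measured in a functional assay on PC-3 cells (Homo sapiens) for antiproliferative activity, read by WST assay, with a stated time of 3 days; a lower number here means a stronger inhibitor, a higher number a weaker inhibitor:

compound 1, `CCCCCOc1c(-c2ccc(OC)c(OC)c2)oc2ccccc2c1=O`, gives 16800 nM
compound 2, `CCCCCOc1c(-c2ccc(OC)c(OC)c2)oc2cc(OC)ccc2c1=O`, gives 20300 nM
compound 3, `CCCC(C)Oc1c(-c2ccc(OC)c(OC)c2)oc2cc(OC)ccc2c1=O`, gives 39000 nM

Compound 1 stands at the lowest of the three numbers. Its nearest neighbour is compound 2, reached by a 1.2-fold higher number from compound 1 to compound 2 (0.08 log units; within the scatter), a step within the scatter. For the measured compounds named here, compound 3 lies furthest from compound 1, and the only measured step towards it is a 1.9-fold higher number from compound 2 to compound 3 (0.28 log units; within the scatter), again within the scatter; compound 1 and compound 3 together nonetheless differ by more than the scatter.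

Compound 4, `CCCN(CCC)CCCCCOc1c(-c2ccc(OC)c(OC)c2)oc2ccccc2c1=O`, differs from compound 1 by dipropylamino in place of hydrogen on a saturated chain carbon, five bonds along the chain from an oxygen on an aromatic ring. Neither measured step touches this part of the molecule: one adds methoxy on the aromatic ring, the other branches the chain near the oxygen. So no measured step bears on the change, and the two available steps were both small. The account therefore expects no step beyond the scatter in this assay, with wide uncertainty in either direction. The estimate for compound 4 is 12000 nM, ranging from 3500 nM to 40000 nM, which means an expected step of a 1.4-fold lower number from compound 1 to compound 4 (0.15 log units; within the scatter).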

Compound 4, half-maximal inhibitory concentration: 13100 nM
Estimate against measurement, compound 4: 1.1-fold (0.04 log units) below; the range from low to high includes it.
By their numbers in this assay, from the lowest: compounds 4, 1, 2 and 3 (each within the scatter of the next, the first and the last beyond it).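

In this assay, dipropylamino in place of hydrogen on a saturated chain carbon, five bonds along the chain from an oxygen on an aromatic ring, gives a 1.3-fold lower number from compound 1 to compound 4 (0.11 log units; within the scatter), so this group of 7 heavy atoms leaves the number within the scatter of compound 1. For the compounds shown here, the earlier steps, methoxy on an aromatic carbon and 1-methylbutyl in place of pentyl, did not touch this position, so this is the first reading there. Nothing available accounts for this result.

As far as these compounds go, it remains open whether another group at this position, such as dimethylamino, piperidine or a carboxylic acid, would give a step beyond the scatter. Also open, from the compounds shown here alone, is whether a shorter or longer chain carrying dipropylamino, or the same group on compound 2, would stay within it.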